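Compound 3: side-chain change at the limit

The source may hold more compounds than are shown below. What is called first, only, known or untested is meant among the compounds shown, and "the series" means these compounds.

compound 1 `CC(C)[C@H](NC(=O)c1cc(Cl)ccc1OCCN)C(=O)Nc1ccc([N+](=O)[O-])cc1Cl`: > 10000 nM
compound 2 `CC(C)[C@H](NC(=O)c1cc(Cl)ccc1OC1CCNCC1)C(=O)Nc1ccc([N+](=O)[O-])cc1Cl`: > 10000 nM

In a functional assay on MCF7 cells (Homo sapiens) for inhibition, read by MTT assay, with a stated time of 72 h (on this read-out lower numbers stand for stronger inhibition and higher numbers for weaker inhibition), compound 1 gives > 10000 nM, which is a limit and not a number. Compound 2 gives > 10000 nM, which is also a limit. Going by the values given here, the position of the series so far is therefore (the limit of > 10000 nM in this assay, at which 2 of the 2 values shown sit), and compound 1 has no numerical value to anchor a comparison.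

Compound 3 `CSCC[C@H](NC(=O)c1cc(Cl)ccc1OCCN)C(=O)Nc1ccc([N+](=O)[O-])cc1Cl` keeps the rest of the structure of compound 1 and differs at one place: 2-(methylsulfanyl)ethyl in place of isopropyl on a saturated chain carbon bound to an amide-type nitrogen and a carbonyl carbon. Among the compounds with values here, the only measured step is a step that the two limits leave unreadable from compound 1 to compound 2. It involves a different place, an oxygen on an aromatic ring, so it does not bear directly on this change and gives no usable size. No step beyond the scatter can be argued in either direction in this assay, so none is expected. The expectation rests on compound 1, whose limit is > 10000 nM. A report of compound 3 as a limit is the likeliest outcome. Compound 3 is estimated at 15000 nM, with an expected range of 6000 nM to 40000 nM. The expected step is a step that the limit leaves unreadable from compound 1 to compound 3.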

Compound 3, half-maximal inhibitory concentration: > 10000 nM
Compound 3 was reported as a limit; the forecaster's own chance of this, stated with the estimate: 70%; the middle value lies beyond the limit too.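

In this assay compound 3 gives > 10000 nM as a limit and not a number. Compound 1 is also reported as a limit, so no step can be read between compound 1 and compound 3. The series stands as follows: the limit of > 10000 nM in this assay, at which 3 of the 3 values shown sit. Still open, as far as these compounds go, is how far each of the three compounds lies from that limit.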